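Chloro for fluoro: the step from compound 2 to compound 3

A few compounds are considered here, and "the series" means these few. Any claim that something is new, unique, unknown or untested is made for them only; others in the source may bear on it.

Compound 1 `Fc1ccc(-c2[nH]c3cc(Cl)ccc3c2Cn2ccnc2)cc1` at 41500 nM
Compound 2 `COc1ccc(-c2[nH]c3cc(F)ccc3c2Cn2ccnc2)cc1` at > 1000000 nM (a limit)

In an ADME assay on MCF7 cells (Homo sapiens) for cytotoxicity, read by MTT assay, with a stated time of 48 h (on this read-out lower numbers stand for stronger inhibition and higher numbers for weaker inhibition), compound 2 gives > 1000000 nM as a limit of the assay and not a number. Compound 3 `COc1ccc(-c2[nH]c3cc(Cl)ccc3c2Cn2ccnc2)cc1` differs from compound 2 in one place: chloro in place of fluoro on an aromatic carbon. Going by compound 1 at 41500 nM as the only number so far, a step to lower numbers, beyond the scatter, is expected in this assay. The expected step is an at least 10-fold lower number from compound 2 to compound 3 (1.00 log units; beyond the scatter), and its size is uncertain. Compound 3 is estimated at 100000 nM within an expected range of 15000 nM to 1000000 nM in this read-out.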

Compound 3, half-maximal inhibitory concentration: > 1000000 nM
Compound 3 gave a limit, no number; the forecaster's own chance of this, stated with the estimate: 30%; middle value at least 10-fold (1.00 log units) away from the limit.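

In this assay, exchanging the fluoro for a methoxy group, with chloro kept on the shared core, gives an at least 24-fold higher number from compound 1 to compound 3 (1.38 log units; beyond the scatter), a large change beyond the scatter. Chloro in place of fluoro on the core thus does not restore a readable number while methoxy stays. The step between compound 2 and compound 3 cannot be read, since both stand at a limit: the limit of > 1000000 nM in this assay, at which 2 of the 3 values shown sit.

On these data alone, what chloro in place of fluoro does on its own remains open, as does whether an amine or a carboxylic acid in place of methoxy would give a number in this assay.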